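Swapping trifluoromethyl for methoxy on a styryl lactone

The compounds below may be only part of what the source reports. "The series", "measured", "known", "first", "only" and "open" are said of these compounds alone.

Measured compounds:
Compound 1, `O=C1C=COC(/C=C/c2ccccc2)C1`: 58.2 uM
Compound 2, `COc1ccc(/C=C/C2CC(=O)C=CO2)cc1`: 87.4 uM
Compound 3, `O=C1C=CCC(/C=C/c2ccc(C(F)(F)F)cc2)O1`: 167 uM

These values come from a functional assay on OVCAR-3 cells (Homo sapiens) for inhibition, read by sulforhodamine B assay, with a stated time of 48 h; a higher number here means a weaker inhibitor of growth, a lower number a stronger inhibitor of growth. Compound 3 shows the highest of the three numbers, though its gap to compound 2 is within the scatter; only its gap to compound 1 lies beyond the scatter. Compound 4, `COc1ccc(/C=C/C2CC=CC(=O)O2)cc1`, keeps the core of compound 3 and differs from it in one place: methoxy in place of trifluoromethyl on an aromatic carbon. For the measured compounds named here, no measured step replaces trifluoromethyl with methoxy. Going by the values given here, the only step in the set that introduces methoxy, a 1.5-fold higher number from compound 1 to compound 2 (0.18 log units; within the scatter), was within the scatter, and it runs on the other core. Compound 2 carries the same methoxy-bearing aryl group as compound 4, and its number in this assay is below that of compound 3, within the scatter. On that basis the step of a 1.4-fold lower number from compound 3 to compound 4 (0.14 log units; within the scatter) is expected to be small, if anything toward a lower number. Compound 4 is therefore estimated to give 120 uM in this assay, with a range from 50 uM to 300 uM.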

Compound 4, concentration for growth inhibition (reported as GI): 61.5 uM
Beside the measured number, compound 4's estimate is 2.0-fold (0.29 log units) above it; the range from low to high includes it.
By their numbers in this assay, from the lowest: compounds 1, 4, 2 and 3 (each within the scatter of the next, the first and the last beyond it).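

In this assay, the change at this place on the aromatic ring, para to a group of 9 heavy atoms, gives a 2.7-fold lower number from compound 3 to compound 4 (0.43 log units; beyond the scatter). For the compounds shown here, this is a modest step, but it shows that, on the core of compound 3, a methoxy-bearing compound can be told apart from its trifluoromethyl partner, which the only earlier step, a 1.5-fold higher number from compound 1 to compound 2 (0.18 log units; within the scatter), a swap of methoxy for hydrogen on the other core, could not show for any change at this place. Nothing measured here accounts for the size or direction of this step.

It remains open whether the step reflects the loss of trifluoromethyl or the gain of methoxy, as the compounds shown include no partner with hydrogen at this place on the core of compound 3. Also open, on these data alone, is how this place would respond to an amine, a carboxylic acid or a longer ether chain.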